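Aryl for alkyl on the alkyne: expectation for compound 4

A few compounds are considered here, and "the series" means these few. Any claim that something is new, unique, unknown or untested is made for them only; others in the source may bear on it.

Three compounds of this set have numbers in a functional assay on HepG2 cells (Homo sapiens) for antiproliferative activity, read by MTT assay, with a stated time of 3 days; on this read-out lower numbers stand for stronger inhibition and higher numbers for weaker inhibition. Compound 1 `CCCCCCCCC#Cc1cn(C/C=C/CN2C(=O)c3ccccc3C2=O)c(=O)[nH]c1=O` gives 43000 nM. Compound 2 `CCCCCc1ccc(C#Cc2cn(C/C=C\CN3C(=O)c4ccccc4C3=O)c(=O)[nH]c2=O)cc1` gives 18000 nM. Compound 3 `CCCCCC#Cc1cn(C/C=C/CN2C(=O)c3ccccc3C2=O)c(=O)[nH]c1=O` gives 9000 nM, the lowest number of the three; compound 2 sits within the scatter of it, compound 1 beyond. Among the measured compounds shown here, the one single-site step so far, a 4.8-fold lower number from compound 1 to compound 3 (0.68 log units; beyond the scatter), is a modest shift and shows that a shorter chain on the alkyne goes with a lower number.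

Compound 4 `CCCCCc1ccc(C#Cc2cn(C/C=C/CN3C(=O)c4ccccc4C3=O)c(=O)[nH]c2=O)cc1` is not yet measured. It differs from compound 3 by 4-pentylphenyl in place of pentyl on a triple-bonded carbon. For the measured compounds named here, no measured step covers this exact exchange. The step of a 4.8-fold lower number from compound 1 to compound 3 (0.68 log units; beyond the scatter) is the only one that bears on it, and only loosely, since it concerns chain length rather than a ring; it argues that a larger group on the alkyne tends to raise the number. The 4-pentylphenyl group of compound 4 is also the group carried by compound 2, and compound 2 gives 18000 nM, a number within the scatter of compound 3, so no large move is indicated either way.

For compound 4 the expectation in this assay is a small upward step, a 1.7-fold higher number from compound 3 to compound 4 (0.22 log units; within the scatter), within or just at the scatter. The estimated value for compound 4 is 15000 nM, with a range from 6000 nM to 40000 nM.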

Compound 4, half-maximal inhibitory concentration: 4300 nM
For compound 4 the middle estimate is 3.5-fold (0.54 log units) above the measured one, outside the stated range (below it).
By their numbers in this assay, from the lowest: compound 4; then compounds 3 and 2 (each within the scatter of the next); then compound 1.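

In this assay, among the compounds shown here, 4-pentylphenyl in place of pentyl on the triple-bonded carbon gives a 2.1-fold lower number from compound 3 to compound 4 (0.32 log units; beyond the scatter), so a larger group at this position does not always raise the number, even though the only earlier step, a 4.8-fold lower number from compound 1 to compound 3 (0.68 log units; beyond the scatter), pointed that way. The widest step in the set is a 10-fold lower number from compound 1 to compound 4 (1.00 log units; beyond the scatter), with 4-pentylphenyl in place of octyl, which suggests that the kind of group on the alkyne counts here and not only its size. The double bond also matters, with the E form in compound 4 carrying the lower number, and a 4.2-fold lower number from compound 2 to compound 4 (0.62 log units; beyond the scatter) can be assigned to that geometry alone because nothing else changes: the fact that compounds 2 and 4 differ only in the configuration as drawn.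

Going by these compounds, it remains open whether the lower number of compound 4 comes from the aromatic ring or from the pentyl chain on it, and a plain phenyl on the triple-bonded carbon would separate the two. On these data alone, it is equally open whether the difference between the Z and E forms holds when the alkyne carries an alkyl chain such as pentyl, and how a chain shorter than pentyl behaves at this position.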